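Swapping the Hydroxyphenyl for a Pyrrole Ring

A few compounds are considered here, and "the series" means these few. Any claim that something is new, unique, unknown or untested is made for them only; others in the source may bear on it.

Compound 1 `CC1=CC[C@H](C(C)(C)NC(=S)N/N=C/c2ccccc2O)CC1` carries a 2-hydroxyphenyl group on the carbon that is double-bonded to nitrogen. In a functional assay on NCI-H460 cells (Homo sapiens) for inhibition, read by sulforhodamine B assay, with a stated time of 48 h (a lower number here means a stronger inhibitor of growth, a higher number a weaker inhibitor of growth), compound 1 gives 8400 nM, the lowest of the two numbers reported; the nearest is compound 3 `CC1=CC[C@H](C(C)(C)NC(=S)N/N=C/c2ccccc2[N+](=O)[O-])CC1`, which in this assay gives 32700 nM. The step of a 3.9-fold higher number from compound 1 to compound 3 (0.59 log units; beyond the scatter) shows that putting a nitro group where the hydroxy stood weakens growth inhibition modestly. Compound 2 `COc1cc(/C=N/NC(=S)NC(C)(C)[C@H]2CC=C(C)CC2)ccc1O` reaches only a limit of the assay in this assay, > 100000 nM, which is the cut-off described as the limit of > 100000 nM in this assay, at which 1 of the 3 values shown sits, and not a number. Compound 4 `CC1=CC[C@H](C(C)(C)NC(=S)N/N=C/c2ccc[nH]2)CC1` has not yet been measured; it differs from compound 1 by 1H-pyrrol-2-yl in place of 2-hydroxyphenyl on a carbon with a double bond to nitrogen. Among the compounds with values here, the only measured step that bears on this change is a 3.9-fold higher number from compound 1 to compound 3 (0.59 log units; beyond the scatter), which also alters what sits on the carbon double-bonded to nitrogen and removes the hydroxy. Compound 4 loses that hydroxy too, so a modest weakening is expected, estimated as a 2.4-fold higher number from compound 1 to compound 4 (0.38 log units; beyond the scatter). Compound 4 is therefore expected to give about 20000 nM in this assay, most likely between 6000 nM and 70000 nM.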

Compound 4, concentration for total growth inhibition: 57500 nM
Estimate against measurement, compound 4: 2.9-fold (0.46 log units) below; measured number inside the range.
By their numbers in this assay, from the lowest: compound 1; then compounds 3 and 4 (each within the scatter of the next). At a limit, above all of these: compound 2.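

This second replacement on the carbon with a double bond to nitrogen shows that changing the whole ring, not just its substituent, also costs activity in this assay: a 6.8-fold higher number from compound 1 to compound 4 (0.84 log units; beyond the scatter). The 1H-pyrrol-2-yl group has the same count of hydrogen-bond donors as 2-hydroxyphenyl, so keeping that count is not enough to hold the number of compound 1. Compound 3 at 32700 nM and compound 4 at 57500 nM lie within the usual scatter of each other, so the nitro-bearing ring and the pyrrole cannot be told apart here, and nothing measured explains the loss.

From the compounds shown here alone, it remains open how a plain phenyl ring would read at this place, which would separate the loss of the hydroxy from the change of ring. An amine in place of the hydroxy on the phenyl ring is equally untested in what is shown here.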